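The source may report more compounds than this note shows. Statements on the series, on what has been measured and on what is new or still open speak of the compounds shown alone.

The compounds measured in a functional assay on M21 cells (Homo sapiens) for antiproliferative activity, read by sulforhodamine B assay, with a stated time of 48 h (on this read-out higher numbers stand for weaker inhibition and lower numbers for stronger inhibition), are these.
Compound 1 `O=C1NCCN1c1ccc(S(=O)(=O)Nc2ccc(C3CCCCC3)cc2)cc1` gives > 1000 nM, a limit of the assay rather than a number.
Compound 2 `Cc1ccc(NS(=O)(=O)c2ccc(N3CCNC3=O)cc2)cc1C` gives 94 nM.
Compound 3 `O=C1NCCN1c1ccc(S(=O)(=O)Nc2cccc(Cl)c2)cc1` gives 25 nM.

Compound 1 thus stands at the weak end of what has been measured, sitting at the limit of > 1000 nM in this assay, at which 1 of the 3 values shown sits. Compound 4 `CCCCCc1ccc(NS(=O)(=O)c2ccc(N3CCNC3=O)cc2)cc1` differs from it in one place: pentyl in place of cyclohexyl on an aromatic carbon. Within the data shown here, the single measured step, a 3.8-fold lower number from compound 2 to compound 3 (0.58 log units; beyond the scatter), changes the group on the sulfonamide nitrogen, not a group on an aromatic carbon of a six-membered aromatic ring of carbon only, so no measured step bears on this exchange, and compound 1 offers only a limit to anchor it. Compound 4 is therefore expected to remain weak, estimated at 2000 nM with a range from 500 nM to 8000 nM, an expected step that the limit leaves unreadable from compound 1 to compound 4.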

Compound 4, half-maximal inhibitory concentration: 870 nM
Beside the measured number, compound 4's estimate is 2.3-fold (0.36 log units) above it; measured number inside the range.
By their numbers in this assay, from the lowest: compound 3; then compound 2; then compound 4. At a limit, above all of these: compound 1.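

Pentyl on this aromatic carbon, para to a large group, gives a readable number in this assay: compound 4 stands at 870 nM. The exchange for cyclohexyl amounts to an at least 1.1-fold lower number from compound 1 to compound 4 (0.06 log units; that floor lies within the scatter), so these data do not separate the ring from the open chain. Compound 1 holds a limit of the assay, and the true size of the step stays unread: the limit of > 1000 nM in this assay, at which 1 of the 4 values shown sits.

As far as these compounds go, whether a shorter chain such as propyl would give a different number at this place remains open. The same holds for an amine or a carboxylic acid there.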